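Swapping a methoxypyridine for a difluoromethoxyphenyl ring

This account rests on a few compounds, and the source may have more. Where it says the series, first, only, none or still open, it means among the compounds named here.

Measured so far in an in vitro ADME assay on microsomes from liver (Mus musculus) for pharmacokinetics (on this read-out lower numbers stand for slow clearance and higher numbers for fast clearance), are these:

Compound 1 `CC(C)(C)C1CCNC(=O)C(N(Cc2ccc(C(=O)NC3CC3)cc2)S(=O)(=O)c2ccc(Cl)cc2)C1` gives 110 mL.min-1.g-1
Compound 2 `COc1ccc(CN([C@@H]2CC(F)(F)CCNC2=O)S(=O)(=O)c2ccc(Cl)cc2)cn1` gives 72 mL.min-1.g-1

Compound 2 stands level with compound 1. The gap between their numbers lies within the usual scatter of repeated measurements. The two cannot be told apart on this read-out.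

Compound 3 `COc1ccc(CN([C@@H]2CC(F)(F)CCNC2=O)S(=O)(=O)c2ccc(Cl)cc2)c(F)c1F` differs from compound 2 in one place, on a saturated chain carbon bound to a sulfonamide nitrogen. There, 2,3-difluoro-4-methoxyphenyl stands in place of 6-methoxypyridin-3-yl (2,3-difluoro-4-methoxyphenyl in place of 6-methoxypyridin-3-yl on a saturated chain carbon bound to a sulfonamide nitrogen). Going by the values given here, no measured pair shows this change on its own, so the data offer no direct guide to its size. The estimated step of a 1.3-fold higher number from compound 2 to compound 3 (0.10 log units; within the scatter) is expected to lean slightly upward and to stay within the scatter. For compound 3 the expected value in this assay is 90 mL.min-1.g-1 (estimated range 45 mL.min-1.g-1 to 180 mL.min-1.g-1).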

Compound 3, intrinsic clearance in microsomes: 121 mL.min-1.g-1
The estimate for compound 3 lay 1.3-fold (0.13 log units) below the measured number, within the range that was stated.
By their numbers in this assay, from the lowest: compounds 2, 1 and 3 (each within the scatter of the next).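

Going by these compounds alone, compound 2 and compound 3 form the first pair here that differs in only one place, so this change can now be read directly in this assay. On a saturated chain carbon bound to a sulfonamide nitrogen, 2,3-difluoro-4-methoxyphenyl in place of 6-methoxypyridin-3-yl gives a 1.7-fold higher number from compound 2 to compound 3 (0.23 log units; within the scatter). This exchange of a ring with one nitrogen for an all-carbon ring with two fluorines therefore cannot be told apart from no change on this read-out, and no available measurement speaks to what lies behind the two numbers.

Going by these compounds, it remains open whether a ring bearing an amine or a carboxylic acid at this place would give a step beyond the scatter. A methoxyphenyl ring without fluorine could help separate the part played by the ring nitrogen from that of the two fluorines.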